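A larger side group on a shared core

A few compounds are considered here, and "the series" means these few. Any claim that something is new, unique, unknown or untested is made for them only; others in the source may bear on it.

Among the measured compounds shown here, in a functional assay on MCF7 cells (Homo sapiens) for inhibition, read by MTT assay, with a stated time of 48 h (a higher number here means a weaker inhibitor, a lower number a stronger inhibitor), compound 2 `CCOC(=O)C1=C(N/N=C(\C#N)C(N)=O)Nc2[nH]nc(C)c2C1c1ccc(N(C)C)cc1` gives 50100 nM and has the highest number so far, though it sits within the scatter of compound 1 `CCOC(=O)C1=C(N/N=C(/C#N)C(=O)OCC)Nc2[nH]nc(C)c2C1c1ccc(N(C)C)cc1` at 35600 nM and clearly above compound 3 `CCOC(=O)C1=C(N/C=N/c2ncc(-c3ccccc3)s2)Nc2[nH]nc(C)c2C1c1ccc(N(C)C)cc1` at 10100 nM on the same scale. Compound 4 `CCOC(=O)C1=C(N/N=C(/Cl)c2ccc([N+](=O)[O-])cc2)Nc2[nH]nc(C)c2C1c1ccc(N(C)C)cc1` carries a group of 12 heavy atoms (7 carbon, 2 nitrogen, 2 oxygen, 1 chlorine; one six-membered aromatic ring of carbon only) in place of a group of 7 heavy atoms (3 carbon, 3 nitrogen, 1 oxygen; no ring), on an amine nitrogen and otherwise keeps the structure of compound 2. For the measured compounds named here, the one measured step at this place is a 1.4-fold higher number from compound 1 to compound 2 (0.15 log units; within the scatter) and it exchanges one group without a ring for another, so it says little about a change that brings in an aromatic ring. The closest guide is compound 3 at 10100 nM as its group at this place also contains aromatic rings, although that group is a different one. A modest move towards a lower number is therefore expected, and the estimated change is a 2.3-fold lower number from compound 2 to compound 4 (0.36 log units; beyond the scatter) in this assay with real uncertainty. For compound 4 the estimated value is 22000 nM (expected range 7000 nM to 60000 nM).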

Compound 4, half-maximal inhibitory concentration: 52700 nM
Compound 4: middle estimate off by 2.4-fold (0.38 log units), on the low side, and the stated range covers the measured number.
By their numbers in this assay, from the lowest: compound 3; then compounds 1, 2 and 4 (each within the scatter of the next).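

In this assay, a group with one six-membered aromatic ring of carbon only on this amine nitrogen does not separate compound 4 from the groups without a ring: the swap gives a 1.1-fold higher number from compound 2 to compound 4 (0.02 log units; within the scatter), and against the other ring-free group it gives a 1.5-fold higher number from compound 1 to compound 4 (0.17 log units; within the scatter). An aromatic ring in the group is therefore not enough on its own to reach the clearly lower number of compound 3, 10100 nM, whose group at this place also holds aromatic rings. Nothing available explains this flat result.

Which part of the group in compound 3 goes with its lower number stays open. Also open, going by these compounds, is how a simple amine, a carboxylic acid or a longer carbon chain would read at this place.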